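Lengthening the chain from compound 3 to compound 4

The source may hold more compounds than are shown below. What is called first, only, known or untested is meant among the compounds shown, and "the series" means these compounds.

Values in an ADME assay on FHC cells (Homo sapiens) for cytotoxicity, read by MTT assay, with a stated time of 72 h; a lower number here means a stronger inhibitor, a higher number a weaker inhibitor (each one a limit)
- compound 1 `C=CC(=O)Nc1cc2c(Nc3ccc(F)c(Cl)c3)ncnc2cc1OCc1cn(CCC(=O)NO)nn1` gives > 25000 nM
- compound 2 `C=CC(=O)Nc1cc2c(Nc3cccc(Cl)c3F)ncnc2cc1OCc1cn(CCCCC(=O)NO)nn1` gives > 25000 nM
- compound 3 `C=CC(=O)Nc1cc2c(Nc3ccc(F)c(Cl)c3)ncnc2cc1OCc1cn(CCCC(=O)NO)nn1` gives > 25000 nM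

Compound 3 gives > 25000 nM as a limit, and all three compounds sit at the same point (the limit of > 25000 nM in this assay, at which 3 of the 3 values shown sit). The next structure is compound 4 `C=CC(=O)Nc1cc2c(Nc3ccc(F)c(Cl)c3)ncnc2cc1OCc1cn(CCCCC(=O)NO)nn1`, where (hydroxycarbamoyl)methyl replaces hydroxycarbamoyl on a saturated chain carbon, three bonds along the chain from an aromatic nitrogen ((hydroxycarbamoyl)methyl in place of hydroxycarbamoyl on a saturated chain carbon, three bonds along the chain from an aromatic nitrogen). Among the measured compounds shown here, the one measured step of this kind (a step that the two limits leave unreadable from compound 1 to compound 3) has no readable size. Compound 2, carrying the 4-(hydroxycarbamoyl)butyl chain, also gives > 25000 nM as a limit. No step beyond the scatter and no direction is expected in this assay (a step that the limit leaves unreadable from compound 3 to compound 4). Compound 4 is estimated at 35000 nM (range 15000 nM to 80000 nM) and is expected to be reported as a limit.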

Compound 4, half-maximal inhibitory concentration: > 25000 nM
Compound 4 ended at the assay's limit (the forecaster's own chance of this, stated with the estimate: 85%); the middle value lies beyond the limit too.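

In this assay compound 4 gives > 25000 nM, which is a limit. The steps to compound 4 from compound 1, compound 2 and compound 3 therefore cannot be read. How far any of these four compounds lies beyond that point stays open: the limit of > 25000 nM in this assay, at which 4 of the 4 values shown sit.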